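Catechol vinyl sulfones: ring versus chain on the sulfonyl carbon

The source may report more compounds than this note shows. Statements on the series, on what has been measured and on what is new or still open speak of the compounds shown alone.

Measured so far in a functional assay, read by fluorescence and spectrophotometry, with a stated time of 1 h; on this read-out higher numbers stand for an effect only at larger amounts of compound and lower numbers for an effect already at smaller amounts:
compound 1 `C=CCCCCCS(=O)(=O)/C=C/c1ccc(O)c(O)c1`, 7100 nM
compound 2 `O=S(=O)(/C=C/c1ccc(O)c(O)c1)CC1CCCC1`, 9400 nM
compound 3 `CCCCCCS(=O)(=O)/C=C/c1ccc(O)c(O)c1`, 7300 nM

Within this set compound 3 gives the second highest of the three numbers. Its nearest neighbour is compound 1, a 1.0-fold higher number from compound 1 to compound 3 (0.01 log units; within the scatter), and its furthest is compound 2, a 1.3-fold lower number from compound 2 to compound 3 (0.11 log units; within the scatter). All three values sit inside the scatter of one another, so no order among them can be read from these data.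

Compound 4 `O=S(=O)(/C=C/c1ccc(O)c(O)c1)CC1CCCCC1` is the next structure to be measured. The change from compound 3 is cyclohexyl in place of pentyl on a saturated chain carbon bound to a sulfonyl sulfur.

Among the measured compounds shown here, the step that bears most directly on this change is the one between compound 2 and compound 3, a 1.3-fold lower number from compound 2 to compound 3 (0.11 log units; within the scatter), where a cyclopentyl and a pentyl on the same saturated chain carbon bound to the sulfonyl sulfur gave numbers within the scatter. The step from compound 1 to compound 2, a 1.3-fold higher number from compound 1 to compound 2 (0.12 log units; within the scatter), likewise exchanged an open chain for a ring at that carbon without leaving the scatter. The move to cyclohexyl is therefore expected to behave like these ring-for-chain exchanges: no step beyond the scatter in this assay, with at most a slight drift toward a higher number.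

Compound 4 is thus estimated at 8500 nM in this assay, with a range of 4000 nM to 18000 nM, which corresponds to an expected step of a 1.2-fold higher number from compound 3 to compound 4 (0.07 log units; within the scatter).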

Compound 4, half-maximal effective concentration: 7500 nM
For compound 4 the middle estimate is 1.1-fold (0.05 log units) above the measured one; the range from low to high includes it.
By their numbers in this assay, from the lowest: compounds 1, 3, 4 and 2 (each within the scatter of the next).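

In this assay, cyclohexyl in place of pentyl on a saturated chain carbon bound to a sulfonyl sulfur stays within the scatter (a 1.0-fold higher number from compound 3 to compound 4 (0.01 log units; within the scatter)), which extends the ring-for-chain comparison at this place from a cyclopentyl to a six-membered ring. Among the compounds shown here, the first direct exchange of one ring for another here, cyclohexyl in place of cyclopentyl, also stays within the scatter (a 1.3-fold lower number from compound 2 to compound 4 (0.10 log units; within the scatter)), as does cyclohexyl in place of the hex-5-en-1-yl chain, which carries a terminal alkene (a 1.1-fold higher number from compound 1 to compound 4 (0.02 log units; within the scatter)), so neither ring size nor ring-versus-chain separates these four compounds on this read-out. Nothing available gives a reason for this flat reading.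

All four compounds carry groups of carbon and hydrogen only at this place, leaving open whether an amine, a carboxylic acid or a longer chain such as decyl on the same carbon would give a step beyond the scatter. Going by these compounds, the rest of the shared core is also constant across the set, so the effect of a methoxy group in place of one of its hydroxyl groups remains unknown.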